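This account rests on a few compounds, and the source may have more. Where it says the series, first, only, none or still open, it means among the compounds named here.

Measured compounds:
compound 1, `Cc1cc(Cl)c(S(C)(=O)=O)cc1C(=O)N=C(N)N`, 25 nM in a functional assay for inhibition of sodium/hydrogen exchanger (Oryctolagus cuniculus); on this read-out lower numbers stand for stronger inhibition and higher numbers for weaker inhibition
compound 2, `Cc1cc(-c2ccccc2)c(S(C)(=O)=O)cc1C(=O)N=C(N)N`, 19 nM in this assay
compound 3, `CCSc1cc(C)c(C(=O)N=C(N)N)cc1S(C)(=O)=O`, 5.9 nM in this assay

Compound 3 gives the lowest number of the three in this assay; the nearest is compound 2 and the furthest compound 1, and both steps to compound 3 lie beyond the scatter, a 3.2-fold lower number from compound 2 to compound 3 (0.51 log units; beyond the scatter) and a 4.2-fold lower number from compound 1 to compound 3 (0.63 log units; beyond the scatter). The step from compound 1 to compound 2, a 1.3-fold lower number from compound 1 to compound 2 (0.12 log units; within the scatter), is within the scatter.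

Compound 4, `Cc1cc(OCc2ccccc2)c(S(C)(=O)=O)cc1C(=O)N=C(N)N`, differs from compound 3 at one place on the shared core: benzyloxy in place of ethylsulfanyl on an aromatic carbon

Within the data shown here, the steps that bear on this change are those into compound 3, since both replace a small or an aromatic group at the same aromatic carbon with ethylsulfanyl and both give a modestly lower number. Reading them backwards, removing ethylsulfanyl for a group carrying a six-membered aromatic ring is expected to raise the number in this assay by a modest amount, as the phenyl analogue compound 2 did with 19 nM. Compound 4 is therefore expected to show a step of a 2.7-fold higher number from compound 3 to compound 4 (0.43 log units; beyond the scatter), to an estimated 16 nM with a range from 5 nM to 50 nM.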

Compound 4, half-maximal inhibitory concentration: 28 nM
Compound 4: the middle estimate sits 1.8-fold (0.24 log units) below what was measured; low and high end bracket the measured number.
By their numbers in this assay, from the lowest: compound 3; then compounds 2, 1 and 4 (each within the scatter of the next).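

In this assay, benzyloxy on this aromatic carbon does not keep the lower number seen with ethylsulfanyl, giving a 4.7-fold higher number from compound 3 to compound 4 (0.68 log units; beyond the scatter). Benzyloxy does not separate from the other two groups, with a 1.5-fold higher number from compound 2 to compound 4 (0.17 log units; within the scatter) and a 1.1-fold higher number from compound 1 to compound 4 (0.05 log units; within the scatter), so among the four groups at this position only ethylsulfanyl stands apart, while chloro, phenyl and benzyloxy read alike despite carrying different numbers of heavy atoms. No measured information is available to explain this difference.

Still open, from the compounds shown here alone, is whether the lower number of compound 3 goes with the sulfur link or with the short chain, since benzyloxy changes both at once; an ethoxy or a benzylsulfanyl group on this carbon would separate the two. Going by these compounds, the response to a longer chain such as butylsulfanyl, or to an amine here, also remains unknown.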